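Working notes: from compound 3 to compound 4

This account rests on a few compounds, and the source may have more. Where it says the series, first, only, none or still open, it means among the compounds named here.

Measured compounds:
- compound 1, `COc1ccc(-c2noc(-c3ccccc3)n2)cc1OC1CCCC1`; in a functional assay on PC-3 cells (Homo sapiens) for antiproliferative activity, read by MTT assay, with a stated time of 24 h (a lower number here means a stronger inhibitor, a higher number a weaker inhibitor), compound 1 gives > 1000000 nM, a limit of the assay rather than a number.
- compound 2, `COc1ccc(-c2noc(-c3ccncc3)n2)cc1OC1CCCC1`; in this assay compound 2 gives > 1000000 nM, again a limit.
- compound 3, `COc1ccc(-c2noc(C3CCCN3)n2)cc1OC1CCCC1`; in this assay compound 3 gives > 1000000 nM, also a limit.

Compound 3 therefore stands nowhere that can be ranked: every value shown in this assay is a limit, and (the limit of > 1000000 nM in this assay, at which 3 of the 3 values shown sit). The step that the two limits leave unreadable from compound 1 to compound 2 is unreadable because both ends are limits, as is a step that the two limits leave unreadable from compound 1 to compound 3 and likewise a step that the two limits leave unreadable from compound 2 to compound 3. Going by the values given here, none of the measured steps can be read for size or direction, so none bears on the next change in a way that can be quantified.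

Compound 4, `COc1ccc(-c2noc(C3CCNCC3)n2)cc1OC1CCCC1`, is the next compound. It differs from compound 3 as follows: piperidin-4-yl in place of pyrrolidin-2-yl on an aromatic carbon. With every measured value of the shared core sitting at the limit, the change is expected to leave compound 4 at the same limit, and a number no higher from compound 3 to compound 4 (the limit leaves the size open) is the expected step. Compound 4 is estimated in this assay at 1000000 nM, with a range from 300000 nM to 3000000 nM, most likely reported as a limit only.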

Compound 4, half-maximal inhibitory concentration: > 1000000 nM
Compound 4: no number, only a limit; the forecaster's own chance of this, stated with the estimate: 90%; the middle value lies on the limit itself.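

In this assay, the steps to compound 4 from compound 1, compound 2 and compound 3 cannot be read, since each joins two limits rather than numbers: the limit of > 1000000 nM in this assay, at which 4 of the 4 values shown sit.

The compounds shown leave open how compound 1, compound 2, compound 3 and compound 4 rank against one another, and which change to the shared core would give a number rather than a limit.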